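Amino Substitution in Two Isomeric Series

The source may hold more compounds than are shown below. What is called first, only, known or untested is meant among the compounds shown, and "the series" means these compounds.

Compound 1 `ClCc1ccc(Cn2cnc3c(Cl)ncnc32)cc1` is measured in a functional assay on SF-268 cells (Homo sapiens) for cytotoxicity, read by sulforhodamine B assay, with a stated time of 48 h (on this read-out higher numbers stand for weaker inhibition of growth and lower numbers for stronger inhibition of growth), and gives 640 nM. Compound 2 `Nc1nc(Cl)c2ncn(Cc3ccc(CCl)cc3)c2n1` carries the change amino in place of hydrogen on an aromatic carbon and in this assay gives 1860 nM; the step is a 2.9-fold higher number from compound 1 to compound 2 (0.46 log units; beyond the scatter). Compound 3 `ClCc1ccccc1Cn1cnc2c(Cl)ncnc21` has the same atoms as compound 1 joined differently; the difference between the two cores is not broken down here. In this assay compound 3 gives 3230 nM, the highest of the three numbers, though compound 2 lies within the usual scatter of it. Compound 4 `Nc1nc(Cl)c2ncn(Cc3ccccc3CCl)c2n1` is not yet measured and differs from compound 3 by amino in place of hydrogen on an aromatic carbon, the same change at the same place as that between compound 1 and compound 2. Compound 4 is expected to show a step of a 2.6-fold higher number from compound 3 to compound 4 (0.42 log units; beyond the scatter) in this assay because a 2.9-fold higher number from compound 1 to compound 2 (0.46 log units; beyond the scatter) was seen for the same change, a single precedent. The estimate for compound 4 in this assay is 8500 nM, within 3500 nM to 21000 nM.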

Compound 4, concentration for 50% growth inhibition: 4680 nM
Beside the measured number, compound 4's estimate is 1.8-fold (0.26 log units) above it; low and high end bracket the measured number.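

In this assay, amino in place of hydrogen on an aromatic carbon gives a 1.4-fold higher number from compound 3 to compound 4 (0.16 log units; within the scatter), so on this core the step cannot be told apart from repeat measurement. The two steps cannot be told apart either, and the data are compatible with the change carrying over from one core to the other: the same change on two cores in this assay, a 2.9-fold higher number (0.46 log units; beyond the scatter) from compound 1 to compound 2 and a 1.4-fold higher number (0.16 log units; within the scatter) from compound 3 to compound 4, 2.0-fold (0.30 log units) apart, within the scatter of two such steps. For the compounds shown here, this does not establish a shared step size, since it rests on only two pairs and only the step on the core of compound 1 is beyond the scatter.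

Open, going by these compounds, is whether a methylamino or hydroxy group at the same place, between two ring nitrogen atoms, would behave like amino. Also open, on these data alone, is whether either core would tolerate a bromo or methoxy group in place of the chloro group.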